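The source may report more compounds than this note shows. Statements on the series, on what has been measured and on what is new or still open speak of the compounds shown alone.

Compound 1, `O=C(/C=C\c1ccc([N+](=O)[O-])cc1)N1N=C(c2ccncc2)OC1c1c[nH]c2ccccc12`, was examined in an ADME assay on HeLa cells (Homo sapiens) for cytotoxicity, read by MTT assay, with a stated time of 72 h; on this read-out lower numbers stand for stronger inhibition of growth and higher numbers for weaker inhibition of growth. In this assay compound 1 gives > 30 ug/mL, which is a limit of the assay rather than a measured number. Compound 2, `O=C(/C=C\c1cccc(F)c1)N1N=C(c2ccncc2)OC1c1c[nH]c2ccccc12`, differs from compound 1 only in the aryl group on the chain, and in this assay compound 2 gives > 30 ug/mL, again a limit rather than a number. The size of the step that the two limits leave unreadable from compound 1 to compound 2 can therefore not be read. Among the measured compounds shown here, the only evidence available is the limit of > 30 ug/mL in this assay, at which 2 of the 2 values shown sit.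

Compound 3, `O=C(/C=C/c1c(Cl)cccc1Cl)N1N=C(c2ccncc2)OC1c1c[nH]c2ccccc12`, has not yet been measured in this assay. Its change from compound 1 is 2-(2,6-dichlorophenyl)ethenyl in place of 2-(4-nitrophenyl)ethenyl on a carbonyl carbon. For the measured compounds named here, the single measured step also exchanges the aryl group on the chain, and its size is unreadable, so there is no basis for expecting a step of any size or direction in this assay beyond the scatter. Compound 3 is therefore expected to sit near the same limit, with the estimated step being a number no higher from compound 1 to compound 3 (the limit leaves the size open). The expected value for compound 3 is 30 ug/mL, in the estimated range 10 ug/mL to 60 ug/mL.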

Compound 3, concentration for 50% growth inhibition: > 30 ug/mL
Compound 3: only a limit was reported (the forecaster's own chance of this, stated with the estimate: 70%); the middle value sits exactly at the limit.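

In this assay compound 3 gives > 30 ug/mL, which is a limit and not a number. The steps from compound 1 and compound 2 to compound 3 therefore cannot be read: the limit of > 30 ug/mL in this assay, at which 3 of the 3 values shown sit. The compounds shown leave open how far apart they truly lie in this assay, and whether changing the aryl group on the chain alters growth inhibition at all.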